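From 2,2,2-trifluoroethyl to fluoromethyl in the series

The source may report more compounds than this note shows. Statements on the series, on what has been measured and on what is new or still open speak of the compounds shown alone.

In an in vitro ADME assay on microsomes from liver (Simiiformes) (a higher number here means that the compound lasts longer, a lower number that the compound disappears faster), compound 1 (`Cc1cc(CCCOc2c(C)cc(-c3noc(C)n3)cc2C)on1`) gives 0.45 h and compound 2 (`Cc1cc(CCCOc2c(C)cc(-c3noc(CC(F)(F)F)n3)cc2C)on1`) gives 0.533 h. Within the data shown here, these two numbers lie within the scatter of each other, so compound 2 cannot be separated from compound 1, the only other measured compound. The next structure is compound 3 (`Cc1cc(CCCOc2c(C)cc(-c3noc(CF)n3)cc2C)on1`), which keeps the shared core and changes one group: fluoro in place of trifluoromethyl on a saturated chain carbon bound to an aromatic carbon. Cut one bond further out, the same change reads as 2,2,2-trifluoroethyl to fluoromethyl.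

Among the measured compounds shown here, one measured step bears on this change: a 1.2-fold higher number from compound 1 to compound 2 (0.07 log units; within the scatter). It placed trifluoromethyl in place of hydrogen at that same kind of carbon and stayed within the scatter. For the measured compounds named here, no measured compound carries fluoro there, so the evidence for this group is indirect. In this assay, no step beyond the scatter is expected, and the estimate is a 1.2-fold lower number from compound 2 to compound 3 (0.07 log units; within the scatter). For compound 3 the expected value is 0.45 h, with an estimated range of 0.25 h to 0.8 h.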

Compound 3, half-life: 0.233 h
The estimate for compound 3 lay 1.9-fold (0.29 log units) above the measured number; the whole stated range lies above it.
By their numbers in this assay, from the lowest: compounds 3, 1 and 2 (each within the scatter of the next, the first and the last beyond it).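

In this assay, among these compounds, this position, a saturated chain carbon bound to an aromatic carbon, now gives a step beyond the scatter: fluoro in place of trifluoromethyl produces a 2.3-fold lower number from compound 2 to compound 3 (0.36 log units; beyond the scatter), a modest step, where the only earlier step at this kind of carbon stayed within the scatter. Fluoro in place of hydrogen at the same carbon gives a 1.9-fold lower number from compound 1 to compound 3 (0.29 log units; within the scatter), which is within the scatter, so compound 3 cannot be separated from compound 1, and compound 1 cannot be separated from compound 2; of the three pairs, only compound 2 and compound 3 stand apart. Nothing available explains why this one pair separates.

Still open, going by these compounds, is how this assay reads for other groups at this carbon, such as a hydroxyl, a methoxy, a nitrile or a longer chain, and whether any of them would stand apart from compound 1. Also open, on these data alone, is whether the gap between trifluoromethyl and fluoro at this carbon would persist if another part of the shared core were changed, for example with an amine elsewhere on it.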